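Swapping a ring for an open chain on a quinone ester

The source may report more compounds than this note shows. Statements on the series, on what has been measured and on what is new or still open speak of the compounds shown alone.

Measured so far:
Compound 1 `CC[C@@](C)(O)CC(=O)O[C@H](CC=C(C)C)C1=CC(=O)c2c(O)ccc(O)c2C1=O`: 17900 nM
Compound 2 `CC(C)=CC[C@@H](OC(=O)C1CCCCO1)C1=CC(=O)c2c(O)ccc(O)c2C1=O`: > 100000 nM (a limit of the assay, not a number)

Both compounds were tested in a functional assay on HeLa cells (Homo sapiens) for cytotoxicity, read by MTT assay; a higher number here means a weaker inhibitor, a lower number a stronger inhibitor. Compound 2 sits at > 100000 nM, which is a limit of the assay and not a number. Compound 1 gives a true number, 17900 nM.

The next structure is compound 3 `CCC(C)(O)CC(=O)O[C@H](CC=C(C)C)C1=CC(=O)c2c(O)ccc(O)c2C1=O`. The change is 2-hydroxy-2-methylbutyl in place of oxan-2-yl on a carbonyl carbon. The ring leaves and an open chain enters.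

Among the measured compounds shown here, one measured step bears on this change, and it lies beyond the scatter: an at least 5.5-fold higher number from compound 1 to compound 2 (0.74 log units; beyond the scatter). It is the same exchange of groups, run in the opposite direction. Since compound 2 has only a limit, the true size of that step is not known.

Reversing the exchange should therefore give a lower number in this assay, meaning a stronger inhibitor, with a value close to that of compound 1. The expected change is an at least 5.5-fold lower number from compound 2 to compound 3 (0.74 log units; beyond the scatter). For compound 3 the estimated value is 18000 nM, with an expected range from 8000 nM to 40000 nM.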

Compound 3, half-maximal inhibitory concentration: 25200 nM
For compound 3 the middle estimate is 1.4-fold (0.15 log units) below the measured one; the range from low to high includes it.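

In this assay, putting 2-hydroxy-2-methylbutyl in place of oxan-2-yl on the carbonyl carbon gives an at least 3.9-fold lower number from compound 2 to compound 3 (0.59 log units; beyond the scatter), so the gap between ring and open chain seen with compound 1 now appears with a second open-chain compound. As far as these compounds go, the true size of this step stays unknown, since compound 2 sits at a limit of the assay and not at a number: the limit of > 100000 nM in this assay, at which 1 of the 3 values shown sits. The open chain now also appears with and without a drawn configuration at a stereocentre on a saturated chain carbon, and that comparison reads a 1.4-fold higher number from compound 1 to compound 3 (0.15 log units; within the scatter), so this assay does not separate the two drawings: the fact that one of compounds 1 and 3 is drawn with a defined configuration and the other without, at the place where they differ.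

The entering chain differs from oxan-2-yl both in having no ring and in carrying a hydrogen-bond donor, so the compounds shown cannot say which of the two differences goes with the lower number. From the compounds shown here alone, a plain pentyl chain on the same carbonyl carbon would pull those two differences apart, and the effect of an amine or a carboxylic acid at this place remains open as well.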